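A few compounds are considered here, and "the series" means these few. Any claim that something is new, unique, unknown or untested is made for them only; others in the source may bear on it.

Compound 1 `COc1ccc(C(=O)c2ccc(OC)c3c2OC(C)(C)C=C3)c(NC(=O)CO)c1` and compound 2 `COc1ccc(C(=O)c2ccc(OC)c3c2OC(C)(C)C=C3)c(NC(=O)CN)c1` share one core and differ in a single place: amino in place of hydroxy on a saturated chain carbon bound to a carbonyl carbon. In a functional assay on MCF7 cells (Homo sapiens) for antiproliferative activity, read by MTT assay, with a stated time of 48 h (on this read-out lower numbers stand for stronger inhibition and higher numbers for weaker inhibition), compound 1 gives 320 nM, and compound 2 gives 410 nM, a step of a 1.3-fold higher number from compound 1 to compound 2 (0.11 log units; within the scatter). Compound 3 `C=C(c1cc(OC)c(OC)c(OC)c1)c1ccc(OC)cc1NC(=O)CO` is built on another core; the difference between the two cores is not broken down here. In this assay compound 3 gives 110 nM, the lowest of the three numbers, and its gap to compound 1 as well as to compound 2 is beyond the usual scatter. Compound 4 `C=C(c1cc(OC)c(OC)c(OC)c1)c1ccc(OC)cc1NC(=O)CN` has not yet been measured; it differs from compound 3 by amino in place of hydroxy on a saturated chain carbon bound to a carbonyl carbon, the same change that separates compound 2 from compound 1. Because that earlier step was a 1.3-fold higher number from compound 1 to compound 2 (0.11 log units; within the scatter), the step from compound 3 to compound 4 is expected to be equally small, about a 1.3-fold higher number from compound 3 to compound 4 (0.10 log units; within the scatter). Compound 4 is therefore estimated at 140 nM, in a range from 70 nM to 280 nM.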

Compound 4, half-maximal inhibitory concentration: 190 nM
Compound 4: the middle estimate sits 1.4-fold (0.13 log units) below what was measured; the range from low to high includes it.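

In this assay, putting amino in place of hydroxy on a saturated chain carbon bound to a carbonyl carbon gives a 1.7-fold higher number from compound 3 to compound 4 (0.24 log units; within the scatter) on the second core. Set beside the first core, the change behaves alike on both, with no difference that stands out from the scatter: the same change on two cores in this assay, a 1.3-fold higher number (0.11 log units; within the scatter) from compound 1 to compound 2 and a 1.7-fold higher number (0.24 log units; within the scatter) from compound 3 to compound 4, 1.3-fold (0.13 log units) apart, within the scatter of two such steps. This shows that a small step carried over between these two cores, but two pairs say nothing about a third core, nor why the step stays small.

Still open, on these data alone, is what a dimethylamino group, a carboxylic acid or a longer chain ending in amino would give at this place. As far as these compounds go, whether the step holds in other cell lines also remains open.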